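Swapping Dimethylamino for a Pyrrole Ring

The source may report more compounds than this note shows. Statements on the series, on what has been measured and on what is new or still open speak of the compounds shown alone.

Compound 1 `Cc1c(Nc2nc(N)c3c(C#N)c(N4CCC[C@H]4C)n(C)c3n2)cnn1C` gives 2 nM
Compound 2 `CN(C)c1c(C#N)c2c(N)ncnc2n1C` gives 111 nM

Of these two results in an assay on isolated protein for binding affinity to Leucine-rich repeat serine/threonine-protein kinase 2 (Homo sapiens), read by TR-FRET and LanthaScreen, with a stated time of 2 h (on this read-out lower numbers stand for stronger inhibition and higher numbers for weaker inhibition), compound 2 stands at the higher number, and compound 1 lies far below it, well beyond the usual scatter. Compound 3 `Cn1c(-n2cccc2)c(C#N)c2c(N)ncnc21` has not yet been measured. It differs from compound 2 by 1H-pyrrol-1-yl in place of dimethylamino on an aromatic carbon. For the measured compounds named here, no measured pair shows this exact change, so its size is unknown; a small shift toward a weaker result, or none beyond the scatter, seems likely. The expected step is a 1.4-fold higher number from compound 2 to compound 3 (0.13 log units; within the scatter). Compound 3 is expected to give about 150 nM, in a range from 40 nM to 600 nM.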

Compound 3, inhibition constant: 239 nM
The estimate for compound 3 lay 1.6-fold (0.20 log units) below the measured number, and the stated range covers the measured number.
By their numbers in this assay, from the lowest: compound 1; then compound 2; then compound 3.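

Replacing dimethylamino with 1H-pyrrol-1-yl on this aromatic carbon brings a 2.2-fold higher number from compound 2 to compound 3 (0.33 log units; beyond the scatter) in this assay. The position therefore still tolerates a larger group carrying a five-membered aromatic ring, with only a modest weakening, though the change does not improve binding. Nothing measured here gives a reason for this shift. The compounds shown leave open how a morpholine or piperidine ring would fare at this position on the same core. They also leave open whether this step would keep its size on the core of compound 1.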